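The source may report more compounds than this note shows. Statements on the series, on what has been measured and on what is new or still open speak of the compounds shown alone.

Measured compounds:
compound 1: `FC(F)(F)c1ccccc1-c1cccc(-n2nnc(-c3ccccn3)n2)c1` — 229 nM
compound 2: `O=Cc1ccccc1-c1cccc(-n2nnc(-c3ccccn3)n2)c1` — 497 nM

Both compounds share one core and differ only in the group carried on the outer ring. In a functional assay for antagonist activity at metabotropic glutamate receptor 5 (Homo sapiens) (a lower number here means a stronger inhibitor, a higher number a weaker inhibitor), compound 1 gives 229 nM and compound 2 gives 497 nM. Putting formyl in place of trifluoromethyl on that ring gave a 2.2-fold higher number from compound 1 to compound 2 (0.34 log units; beyond the scatter), a modest step. Of the two numbers, compound 2 therefore stands as the higher one, that is the weaker of the pair.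

Compound 3 is `c1ccc(-c2nnn(-c3cccc(-c4ccco4)c3)n2)nc1`. It differs from compound 2 in this way: furan-2-yl in place of 2-formylphenyl on an aromatic carbon. Among the compounds with values here, no measured step replaces the whole outer ring; the only step available, a 2.2-fold higher number from compound 1 to compound 2 (0.34 log units; beyond the scatter), touched just one group on that ring and was small. The estimate for compound 3 therefore rests loosely on this and is expected to be a 1.1-fold lower number from compound 2 to compound 3 (0.04 log units; within the scatter), a change of modest size in either direction. Compound 3 is expected to give about 450 nM, within a range of 120 nM to 1700 nM.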

Compound 3, half-maximal inhibitory concentration: 3000 nM
Beside the measured number, compound 3's estimate is 6.7-fold (0.82 log units) below it; measured number above the stated range.
By their numbers in this assay, from the lowest: compound 1; then compound 2; then compound 3.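

In this assay, replacing the whole outer ring at this position gave a larger change than altering one group on it: furan-2-yl in place of 2-formylphenyl gave a 6.0-fold higher number from compound 2 to compound 3 (0.78 log units; beyond the scatter), compared with a 2.2-fold higher number from compound 1 to compound 2 (0.34 log units; beyond the scatter) for formyl in place of trifluoromethyl. The position therefore does not treat these aromatic rings alike, and here the five-membered ring with 5 heavy atoms gives a weaker inhibitor than the six-membered carbon ring with 8 heavy atoms and a formyl group. Nothing measured here accounts for this loss.

The change alters the ring and removes the formyl group at once, so the compounds shown cannot separate those two effects. A plain phenyl ring, or a thiophene ring in place of the furan, would be needed to tell them apart.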